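This account rests on a few compounds, and the source may have more. Where it says the series, first, only, none or still open, it means among the compounds named here.

Three compounds share one core and differ only in the aryl group bound to the double-bonded chain carbon. Compound 1 `CC/C(=C(/c1ccc(/C=C/C(=O)O)cc1)c1cc2ccccc2[nH]1)c1cccc(Cl)c1Cl` gives 898 nM in a functional assay on MCF7 cells (Homo sapiens) for inhibition (on this read-out higher numbers stand for weaker inhibition and lower numbers for stronger inhibition), compound 2 `CC/C(=C(/c1ccc(/C=C/C(=O)O)cc1)c1cc2ccccc2[nH]1)c1ccc(Cl)cc1Cl` gives 11 nM, and compound 3 `CC/C(=C(/c1ccc(/C=C/C(=O)O)cc1)c1cc2ccccc2[nH]1)c1ccc(Cl)cc1C#N` gives 14 nM, so compound 3 stands second highest of the three, close to compound 2 and far from compound 1. The change to compound 4 `CC/C(=C(/c1ccc(/C=C/C(=O)O)cc1)c1cc2ccccc2[nH]1)c1c(C)cccc1Cl` is 2-chloro-6-methylphenyl in place of 4-chloro-2-cyanophenyl on a double-bonded chain carbon bound to a double-bonded chain carbon and a saturated chain carbon. Among the measured compounds shown here, no measured step tests this group, but the steps of an 82-fold lower number from compound 1 to compound 2 (1.91 log units; beyond the scatter) and a 64-fold lower number from compound 1 to compound 3 (1.81 log units; beyond the scatter) show that rearranging the ring substituents can move this assay by a large amount, while a 1.3-fold higher number from compound 2 to compound 3 (0.10 log units; within the scatter) shows a small one. Compound 4 is therefore expected to give a higher number, a 14-fold higher number from compound 3 to compound 4 (1.15 log units; beyond the scatter), with wide uncertainty, estimated at 200 nM within 30 nM to 1500 nM.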

Compound 4, half-maximal inhibitory concentration: 30 nM
For compound 4 the middle estimate is 6.7-fold (0.82 log units) above the measured one; measured number inside the range.
By their numbers in this assay, from the lowest: compounds 2 and 3 (each within the scatter of the next); then compound 4; then compound 1.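

Swapping in 2-chloro-6-methylphenyl costs little against the two lowest compounds in this assay, with a 2.1-fold higher number from compound 3 to compound 4 (0.33 log units; beyond the scatter) and a 2.7-fold higher number from compound 2 to compound 4 (0.44 log units; beyond the scatter), yet it keeps most of the large gain seen in a 30-fold lower number from compound 1 to compound 4 (1.48 log units; beyond the scatter). A low number at this place therefore does not require the 4-chloro group that compound 2 and compound 3 share, nor the nitrile of compound 3. Still, neither of those two compounds is matched.

Nothing available explains why these aryl groups differ. On these data alone, whether an amine or a methoxy group on this ring would give a number nearer compound 2 or compound 1 remains open.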